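The compounds below may be only part of what the source reports. "The series", "measured", "known", "first", "only" and "open" are said of these compounds alone.

Measured so far in a functional assay on HCT-116 cells (Homo sapiens) for antiproliferative activity, read by MTT assay, with a stated time of 72 h; a lower number here means a stronger inhibitor, a higher number a weaker inhibitor:
- compound 1 `O=S(=O)(c1ccc(-c2cnc(C3CC3)o2)cc1)N1CCCOc2ccc(F)cc21` — 24 nM
- compound 2 `O=S(=O)(c1ccc(-c2cnc(C3CC3)o2)cc1)N1CCOCc2ccccc21` — 187 nM

Compound 1 holds the lowest of the two numbers; compound 2 stands beyond the scatter from it. The two differ in more than one place, so no single step can be read from the pair, and the size of a one-point change in this series is not known from these data.

Compound 3 `COc1ccc2c(c1)N(S(=O)(=O)c1ccc(-c3cnc(C4CC4)o3)cc1)CCCO2` is the next compound, differing from compound 1 by methoxy in place of fluoro on an aromatic carbon. Without a measured single-point step to lean on, only a modest step is expected here, in the weakening direction, roughly a 1.7-fold higher number from compound 1 to compound 3 (0.22 log units; within the scatter) from compound 1 to compound 3, though a result within the scatter would not surprise. For compound 3 the estimated value in this assay is 40 nM, expected to fall between 12 nM and 130 nM.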

Compound 3, half-maximal inhibitory concentration: 47 nM
Estimate against measurement, compound 3: 1.2-fold (0.07 log units) below, within the range that was stated.
By their numbers in this assay, from the lowest: compounds 1 and 3 (each within the scatter of the next); then compound 2.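

In this assay, going by these compounds alone, methoxy in place of fluoro on an aromatic carbon gives a 2.0-fold higher number from compound 1 to compound 3 (0.29 log units; within the scatter) and so supplies the first single-place step, a step that stays within the scatter. At this position, meta to a fused ring and para to a fused ring, the two groups cannot be told apart in this assay, even though methoxy brings one more heavy atom and one hydrogen-bond acceptor. No measured evidence at hand accounts for this result.

Still open, as far as these compounds go, is whether this position tolerates other kinds of group, such as an amine or a carboxylic acid, on the same aromatic carbon. A longer chain such as ethoxy or butoxy would show whether the same tolerance extends beyond methoxy.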